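Cytotoxicity notes: aryl isoxazoline diols, compound 3 to compound 4

The source may hold more compounds than are shown below. What is called first, only, known or untested is meant among the compounds shown, and "the series" means these compounds.

Measured compounds in a functional assay on HeLa cells (Homo sapiens) for cytotoxicity, read by MTT assay, with a stated time of 48 h; a lower number here means a stronger inhibitor, a higher number a weaker inhibitor:
- compound 1, `OC[C@@H]1C[C@H](CO)[C@@H]2C(c3ccccc3Cl)=NO[C@H]12`: > 50 ug/mL
- compound 2, `COc1ccc(C2=NO[C@@H]3[C@H](CO)C[C@H](CO)[C@H]23)cc1OC`: > 50 ug/mL
- compound 3, `OC[C@@H]1C[C@H](CO)[C@@H]2C(c3ccc(Cl)cc3)=NO[C@H]12`: > 50 ug/mL

The three measured compounds share one core and differ only in the substitution of the aryl ring. For compound 1 the value in this assay is a limit of the assay, not a number. For compound 2 the value is likewise a limit. For compound 3 the value is again a limit, so compound 3 stands where every measured compound of the series stands: at the limit of > 50 ug/mL in this assay, at which 3 of the 3 values shown sit. Among the compounds with values here, no measured pair differs in a single place, so no measured step is available, and the values show only that none of the three reaches a number within the tested range.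

Compound 4, `OC[C@@H]1C[C@H](CO)[C@@H]2C(c3ccc(F)cc3)=NO[C@H]12`, is not yet measured in this assay. It differs from compound 3 as follows: fluoro in place of chloro on an aromatic carbon. With all three measured values sitting at the limit, no direction can be read from the series. The step from compound 3 to compound 4 is expected to be a step that the limit leaves unreadable from compound 3 to compound 4, that is, none beyond the scatter. Compound 4 is therefore estimated at 60 ug/mL, with a range from 30 ug/mL to 150 ug/mL, and most likely the assay will again report only a limit.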

Compound 4, half-maximal inhibitory concentration: > 50 ug/mL
Compound 4: only a limit was reported (the forecaster's own chance of this, stated with the estimate: 85%); the middle value does not contradict the limit.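

In this assay compound 4 gives > 50 ug/mL, a limit and not a number. Within the data shown here, compound 3 also carries a limit, so no step from compound 3 to compound 4 can be read. The compounds shown leave open whether any aryl substitution changes cytotoxicity, because all stand at one limit: the limit of > 50 ug/mL in this assay, at which 4 of the 4 values shown sit.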